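A few compounds are considered here, and "the series" means these few. Any claim that something is new, unique, unknown or untested is made for them only; others in the source may bear on it.

Measured compounds in a functional assay on isolated protein for inhibition of Glucose-dependent insulinotropic receptor (Rattus norvegicus), read by HTRF and cAMP accumulation; a lower number here means that less compound is needed, a higher number that more compound is needed for the effect:
compound 1 `Cc1nc(S(C)(=O)=O)ccc1Oc1ncnc(OC2CCN(C(=O)OC3CCC3)CC2)c1F`, 167 nM
compound 2 `Cc1nc(S(C)(=O)=O)ccc1Oc1ncnc(OC2CCN(C(=O)OC3COC3)CC2)c1F`, 2500 nM
compound 3 `Cc1nc(S(C)(=O)=O)ccc1Oc1ncnc(OC2CCN(C(=O)SC(C)(C)C)CC2)c1F`, 30.7 nM

Compound 1 stands second highest of the three numbers; its nearest neighbour is compound 3 with a 5.4-fold lower number from compound 1 to compound 3 (0.74 log units; beyond the scatter), its furthest compound 2 with a 15-fold higher number from compound 1 to compound 2 (1.18 log units; beyond the scatter).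

Compound 4 `Cc1nc(S(C)(=O)=O)ccc1Oc1ncnc(OC2CCN(C(=O)C(C)(C)F)CC2)c1F` is not yet measured. It differs from compound 1 as follows: 1-fluoro-1-methylethyl in place of cyclobutyloxy on a carbonyl carbon. Among the compounds with values here, two measured steps bear on this position on the carbonyl carbon. From compound 1 to compound 3 the step was a 5.4-fold lower number from compound 1 to compound 3 (0.74 log units; beyond the scatter), and from compound 2 to compound 3 an 81-fold lower number from compound 2 to compound 3 (1.91 log units; beyond the scatter), both toward a branched group without a ring. The change to compound 4 also enters a branched, ring-free group, so a modest lowering in this assay is expected: a 2.1-fold lower number from compound 1 to compound 4 (0.32 log units; beyond the scatter). For compound 4 the estimate is 80 nM, within 25 nM to 250 nM.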

Compound 4, half-maximal effective concentration: 296 nM
Beside the measured number, compound 4's estimate is 3.7-fold (0.57 log units) below it, outside the stated range (above it).
By their numbers in this assay, from the lowest: compound 3; then compounds 1 and 4 (each within the scatter of the next); then compound 2.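

In this assay, 1-fluoro-1-methylethyl in place of cyclobutyloxy gives a 1.8-fold higher number from compound 1 to compound 4 (0.25 log units; within the scatter) and so does not reproduce the lowering seen with (tert-butyl)sulfanyl. A branched, ring-free group on the carbonyl carbon is therefore not enough on its own for that lowering. The new group sits apart from both other groups, with a 9.6-fold higher number from compound 3 to compound 4 (0.98 log units; beyond the scatter) and an 8.4-fold lower number from compound 2 to compound 4 (0.93 log units; beyond the scatter) as its steps to them.

Nothing at hand accounts for these differences. From the compounds shown here alone, whether tert-butyloxy or a plain tert-butyl group on the carbonyl carbon would track compound 3 remains open.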